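Shortening the Carbamate Tail of Compound 3

The source may report more compounds than this note shows. Statements on the series, on what has been measured and on what is new or still open speak of the compounds shown alone.

The shared core, seen in compound 3 `CCCc1nc(CC)c(C(=O)OCc2ccccc2C(=O)c2ccccc2)n1Cc1ccc(-c2ccccc2S(=O)(=O)NC(=O)OCCc2ccccc2)cc1`, carries a phenethyloxycarbonyl group on the sulfonamide nitrogen. In an assay on isolated protein for binding affinity to Type-2 angiotensin II receptor (Homo sapiens) (on this read-out lower numbers stand for stronger inhibition and higher numbers for weaker inhibition), compound 3 gives 2.1 nM, the second highest of the three numbers measured. Among the measured compounds shown here, compound 1 `CCCc1nc(CC)c(C(=O)OCc2ccccc2C(=O)c2ccccc2)n1Cc1ccc(-c2ccccc2S(=O)(=O)NC(=O)OCCc2ccccc2)cc1F` gives 0.69 nM, and the only single-point step known here, a 3.0-fold higher number from compound 1 to compound 3 (0.48 log units; beyond the scatter), concerns a hydrogen in place of fluoro on an aromatic carbon, not the carbamate. Compound 2 `CCCOC(=O)NS(=O)(=O)c1ccccc1-c1ccc(Cn2c(CCC)nc(CC)c2C(=O)OCc2ccccc2-c2ccsc2)c(F)c1`, which gives 20 nM, differs from compound 3 in several places at once, so its higher number cannot be tied to its shorter carbamate alone.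

Compound 4 `CCCc1nc(CC)c(C(=O)OCc2ccccc2C(=O)c2ccccc2)n1Cc1ccc(-c2ccccc2S(=O)(=O)NC(=O)OC)cc1` differs from compound 3 by hydrogen in place of benzyl on a saturated chain carbon bound to an oxygen next to a carbonyl group, that is, phenethyl to methyl. For the measured compounds named here, no measured step bears directly on this change. Removing a whole aromatic ring from a compound in this potency range is expected to weaken binding moderately, so for compound 4 a rise of roughly a 3.8-fold higher number from compound 3 to compound 4 (0.58 log units; beyond the scatter) is expected, with considerable uncertainty. Compound 4 is estimated at 8 nM, between 2 nM and 35 nM.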

Compound 4, half-maximal inhibitory concentration: 10 nM
The estimate for compound 4 lay 1.3-fold (0.10 log units) below the measured number; measured number inside the range.
By their numbers in this assay, from the lowest: compound 1; then compound 3; then compounds 4 and 2 (each within the scatter of the next).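

In this assay, among the compounds shown here, shortening phenethyl to methyl gives a 4.8-fold higher number from compound 3 to compound 4 (0.68 log units; beyond the scatter), the first single-change reading at this end of the carbamate. The position therefore does respond to this change, with the number moving beyond the usual scatter of repeated measurements. The size of the step is modest, so the loss of the benzyl portion, with its aromatic ring, does not remove binding in this assay. No measurement shown explains the rise.

On these data alone, this one step removes the aromatic ring and shortens the chain together, so the share of each in the change stays open. A butyl chain in place of the phenethyl, which keeps a longer chain without an aromatic ring, would begin to separate the two, and a chain ending in an amine would test a different kind of group here.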